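A few compounds are considered here, and "the series" means these few. Any claim that something is new, unique, unknown or untested is made for them only; others in the source may bear on it.

Compound 3 `CC(C)(C)c1cccc(OCC(=O)Nc2ccc(OCC(=O)O)c(F)c2)c1` gives 40.2% in a functional assay on CHO cells for agonist activity at Free fatty acid receptor 1 (Homo sapiens), read by FLIPR, tested at 100 nM (a higher number here means a stronger effect of the compound at the concentration tested, a lower number a weaker effect), the second highest of the three numbers measured. Compound 2 `Cc1cccc(OCC(=O)Nc2ccc(OCC(=O)O)c(F)c2)c1` stands nearest, and in this assay compound 2 gives 45.4%. Compound 1 `O=C(O)COc1ccc(NC(=O)COc2ccccc2)cc1F` stands furthest, and in this assay compound 1 gives 29.8%. Compound 4 `O=C(O)COc1ccc(NC(=O)COc2cccc(C(F)(F)F)c2)cc1F` differs from compound 3 in one place: trifluoromethyl in place of tert-butyl on an aromatic carbon. Two kinds of measured step bear on this. Putting a group on that aromatic carbon in place of hydrogen gave a number 10.4 percentage points higher from compound 1 to compound 3 (beyond the scatter) and a number 15.6 percentage points higher from compound 1 to compound 2 (beyond the scatter), both modest. Exchanging one such group for another gave a number 5.2 percentage points lower from compound 2 to compound 3 (within the scatter), a difference within the scatter. Among the measured compounds shown here, no measured compound carries trifluoromethyl, so there is no direct precedent. The two groups that were tried behaved alike, so only a small step is expected for compound 4, a number 0.2 percentage points lower from compound 3 to compound 4 (within the scatter), most likely within the scatter. Compound 4 is therefore estimated at 40%, with a range from 25% to 55%.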

Compound 4, a percentage reported as activity, at one concentration (the size of the read-out at that concentration, not a potency): 11.4%
The estimate for compound 4 lay 28.6 percentage points above the measured number, outside the stated range (below it).
By their numbers in this assay, from the lowest: compound 4; then compound 1; then compounds 3 and 2 (each within the scatter of the next).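

In this assay this aromatic carbon turns out to be far less forgiving than methyl and tert-butyl suggested: trifluoromethyl enters with the same count of heavy atoms as the tert-butyl it replaces, yet the change gives a number 28.8 percentage points lower from compound 3 to compound 4 (beyond the scatter) and so heavy-atom count alone does not decide the outcome here. Set against methyl the same group gives a number 34 percentage points lower from compound 2 to compound 4 (beyond the scatter) and set against plain hydrogen it gives a number 18.4 percentage points lower from compound 1 to compound 4 (beyond the scatter) so a group on this carbon can lower the read-out as well as raise it. Nothing available explains why trifluoromethyl parts from the other two groups.

Going by these compounds, whether a chlorine atom, a methoxy group or an amine on this carbon would follow methyl and tert-butyl or follow trifluoromethyl remains open. A read-out at a single concentration also leaves open how the potencies of these compounds compare.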